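Three Unreadable Steps Toward a Trifluoromethyl Analogue

A few compounds are considered here, and "the series" means these few. Any claim that something is new, unique, unknown or untested is made for them only; others in the source may bear on it.

Compound 1 `CC(C)N(Cc1cccc(OCCCCCC(=O)O)c1)C(=O)c1ccc(-c2cccc(-c3ccccc3)c2)cc1`: in an ADME assay on Raji cells (Homo sapiens) for cytotoxicity, read by CellTiter-Glo and resazurin assay, with a stated time of 72 h (a higher number here means that more compound is needed for the effect, a lower number that less compound is needed), compound 1 gives > 26000 nM, which is a limit of the assay.
Compound 2 `COc1cc(F)cc(-c2ccc(C(=O)N(Cc3cccc(OCCCCCC(=O)O)c3)C(C)C)cc2)c1`: in this assay compound 2 gives > 26000 nM, again a limit.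
Compound 3 `COc1ccc(F)c(-c2ccc(C(=O)N(Cc3cccc(OCCCCCC(=O)O)c3)C(C)C)cc2)c1`: in this assay compound 3 gives > 26000 nM, also a limit.

Compound 3 therefore stands at a limit only, and the two other values shown share that same limit, as the limit of > 26000 nM in this assay, at which 3 of the 3 values shown sit, records. Compound 4 `CC(C)N(Cc1cccc(OCCCCCC(=O)O)c1)C(=O)c1ccc(-c2cccc(C(F)(F)F)c2)cc1` differs from compound 3 in one place: 3-(trifluoromethyl)phenyl in place of 2-fluoro-5-methoxyphenyl on an aromatic carbon. Among the compounds with values here, three measured steps bear on changes at this same aromatic carbon: a step that the two limits leave unreadable from compound 1 to compound 2, a step that the two limits leave unreadable from compound 1 to compound 3 and a step that the two limits leave unreadable from compound 2 to compound 3. None of them can be read in size, since both ends of each step sit at the limit. Within the data shown here, with every swap of the group at this position so far leaving the value at the limit, the expectation for compound 4 is a step of no readable size, a step that the limit leaves unreadable from compound 3 to compound 4, most likely ending again at a limit. Compound 4 is thus estimated at 30000 nM, within a range from 15000 nM to 80000 nM.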

Compound 4, half-maximal effective concentration: > 26000 nM
Compound 4: only a limit was reported; the forecaster's own chance of this, stated with the estimate: 85%; the middle value does not contradict the limit.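

No step from compound 1, compound 2 or compound 3 to compound 4 can be read in size, since all four compounds share one assay limit: the limit of > 26000 nM in this assay, at which 4 of the 4 values shown sit.

The compounds shown leave open whether any group on this aromatic carbon changes the value in this assay, and by how much.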